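The source may hold more compounds than are shown below. What is called first, only, known or untested is meant among the compounds shown, and "the series" means these compounds.

In a functional assay on MCF7 cells (Homo sapiens) for inhibition, read by trypan blue exclusion, with a stated time of 72 h (on this read-out lower numbers stand for stronger inhibition of growth and higher numbers for weaker inhibition of growth), compound 2 `CC/C(=C(/c1ccccc1)c1ccc(NC(=O)C(C)C)cc1)c1ccccc1` gives > 30000 nM, which is a limit and not a number. Compound 1 `CC/C(=C(\c1ccccc1)c1ccc(NC(=O)C(C)C)cc1)c1ccccc1` differs from compound 2 only in configuration as drawn. Compound 1 gives > 30000 nM, also a limit. That leaves a step that the two limits leave unreadable from compound 1 to compound 2. Compound 3 `CC/C(=C(/c1ccc(O)cc1)c1ccc(NC(=O)C(C)C)cc1)c1ccccc1` gives an actual number, 16400 nM.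

Compound 4 `CC/C(=C(/c1ccccc1)c1ccc(NC(=O)C(C)C)cc1)c1ccc(O)cc1` differs from compound 2 by hydroxy in place of hydrogen on an aromatic carbon, or phenyl to 4-hydroxyphenyl. Compound 3 carries the same kind of change on a different phenyl. Going by the values given here, this makes an at least 1.8-fold lower number from compound 2 to compound 3 (0.26 log units; that floor lies within the scatter) the only measured step that bears on it. That step has a floor within the scatter and no known full size, so only a modest move towards stronger inhibition of growth is expected in this assay, and compound 4 may well stay at the limit. The expected change is an at least 2.1-fold lower number from compound 2 to compound 4 (0.33 log units; beyond the scatter). For compound 4 the estimated value is 14000 nM, with an expected range from 5000 nM to 30000 nM.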

Compound 4, concentration for 50% growth inhibition: 8500 nM
Compound 4: the middle estimate sits 1.6-fold (0.22 log units) above what was measured, and the stated range covers the measured number.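

In this assay, going by these compounds alone, hydroxy in place of hydrogen on an aromatic carbon, para to a large group, gives the first step here that clears the usual scatter: an at least 3.5-fold lower number from compound 2 to compound 4 (0.54 log units; beyond the scatter). The same kind of change on a different phenyl gave only a floor within the scatter, an at least 1.8-fold lower number from compound 2 to compound 3 (0.26 log units; that floor lies within the scatter), and it could not show a real move towards stronger inhibition of growth. From the compounds shown here alone, compound 2 gives > 30000 nM, which is a limit and not a number, and the full size of the new step stays unknown.

The compounds shown leave open how an amine, a methoxy group or a carboxylic acid would read in place of this hydroxy. The step between the two compounds at the limit cannot be read, and what configuration alone does stays open: the fact that compounds 1 and 2 differ only in the configuration as drawn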